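Ethylamino for Ethylsulfanyl on a Fused Core

The source may report more compounds than this note shows. Statements on the series, on what has been measured and on what is new or still open speak of the compounds shown alone.

Measured so far:
Compound 1, `CCSc1nc(N)c2nc(O)n(Cc3ccccc3)c2n1`: 0.1 uM
Compound 2, `Cc1ccc(Cn2c(O)nc3c(N)ncnc32)cc1`: 10 uM
Compound 3, `COc1nc2c(N)ncnc2n1Cc1ccccc1`: > 10 uM

In a functional assay (spleen, spleen) for activation, with Mus musculus as the target (on this read-out higher numbers stand for an effect only at larger amounts of compound and lower numbers for an effect already at smaller amounts), compound 1 gives 0.1 uM, the lowest of the two numbers measured. Compound 2 gives 10 uM in this assay, a number that lies above the value of compound 1 by a gap well beyond the usual scatter. For compound 3 this assay reports only a limit, > 10 uM, and not a number; at this limit sits (the limit of > 10 uM in this assay, at which 1 of the 3 values shown sits). Among the measured compounds shown here, no two of these measured compounds differ in just one place, so no single measured step is available.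

The next compound, compound 4, `CCNc1nc(N)c2nc(O)n(Cc3ccccc3)c2n1`, differs from compound 1 in one place: ethylamino in place of ethylsulfanyl on an aromatic carbon. For the measured compounds named here, with no measured step to guide the size of this change, a modest shift is expected, if any beyond the scatter, and the direction is uncertain. Compound 4 is estimated to give 0.3 uM in this assay, within a range from 0.05 uM to 3 uM. This estimate means a step of a 3.0-fold higher number from compound 1 to compound 4 (0.48 log units; beyond the scatter) that is expected to stay small.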

Compound 4, minimum effective concentration: 1 uM
The estimate for compound 4 lay 3.3-fold (0.52 log units) below the measured number; measured number inside the range.
By their numbers in this assay, from the lowest: compound 1; then compound 4; then compound 2.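

In this assay, this is the first single change shown at this position, on an aromatic carbon between two ring nitrogen atoms, and ethylamino in place of ethylsulfanyl gives a 10-fold higher number from compound 1 to compound 4 (1.00 log units; beyond the scatter). So the position responds to a swap that leaves the size of the group, counted in heavy atoms, unchanged. The two groups differ in sulfur against nitrogen and in the hydrogen-bond donor that ethylamino brings, and nothing measured here tells which of these differences accounts for the step.

From the compounds shown here alone, it remains open how the number would move with ethoxy, which has oxygen in that place, or with a longer chain such as butylsulfanyl. Also open, going by these compounds, is whether the same swap would give a step of similar size on a core carrying other groups.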